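The source may hold more compounds than are shown below. What is called first, only, known or untested is meant among the compounds shown, and "the series" means these compounds.

Compound 1 `Cn1cncc1CN1CC(N(CC2CCN(C(=O)CNC(=O)OC(C)(C)C)CC2)S(=O)(=O)c2ccccn2)Cc2cc(C#N)ccc21` sits, in an ADME assay on Caco-2 cells (Homo sapiens) for permeability, in the apical to basolateral direction (on this read-out lower numbers stand for lower permeability and higher numbers for higher permeability), at 0.5 10^-6 cm/s, level with compound 2 `Cn1cncc1CN1CC(N(CC2CCN(C(=O)C3CCCC3)CC2)S(=O)(=O)c2ccccn2)Cc2cc(C#N)ccc21` at 0.5 10^-6 cm/s and together the lowest of the three numbers; compound 3 `Cn1cncc1CN1CC(N(CC2CCN(C(=O)OC(C)(C)C)CC2)S(=O)(=O)c2ccccn2)Cc2cc(C#N)ccc21` gives 15.5 10^-6 cm/s. Compound 4 `Cn1cncc1CN1CC(N(CC2CCN(C(=O)Nc3ccc(Br)cc3)CC2)S(=O)(=O)c2ccccn2)Cc2cc(C#N)ccc21` differs from compound 1 by (4-bromophenyl)amino in place of ((tert-butoxycarbonyl)amino)methyl on a carbonyl carbon. Among the compounds with values here, two steps bear on it: no change at the digits printed from compound 1 to compound 2 (within the scatter) and a 31-fold higher number from compound 1 to compound 3 (1.49 log units; beyond the scatter), so exchange of the group on this carbonyl carbon can leave this assay unchanged or move it strongly, and no measured step carries an aromatic ring or a bromine. Since compound 2 shows 0.5 10^-6 cm/s with a different carbonyl substituent, a step of roughly a 3.0-fold higher number from compound 1 to compound 4 (0.48 log units; beyond the scatter) is expected, uncertain in size. Compound 4 is estimated at 1.5 10^-6 cm/s, range 0.4 10^-6 cm/s to 6 10^-6 cm/s.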

Compound 4, apparent permeability: 0.6 10^-6 cm/s
Estimate against measurement, compound 4: 2.5-fold (0.40 log units) above; the range from low to high includes it.
By their numbers in this assay, from the lowest: compounds 1, 2 and 4 (each within the scatter of the next); then compound 3.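

On this carbonyl carbon, (4-bromophenyl)amino puts an aromatic ring and a bromine into the series, yet in this assay it shows a 1.2-fold higher number from compound 1 to compound 4 (0.08 log units; within the scatter) and a 1.2-fold higher number from compound 2 to compound 4 (0.08 log units; within the scatter), both within the scatter. Tert-butoxy alone stands apart, with a 26-fold lower number from compound 3 to compound 4 (1.41 log units; beyond the scatter) as a large step, so compound 3 goes against the level shared by compounds 1, 2 and 4. No evidence accompanying these numbers accounts for that gap.

Open, from the compounds shown here alone, is where a simple amine, a carboxylic acid or a longer chain on this carbonyl carbon would fall. Also open, going by these compounds, is whether methoxy or isopropoxy would follow tert-butoxy.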